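A few compounds are considered here, and "the series" means these few. Any claim that something is new, unique, unknown or untested is made for them only; others in the source may bear on it.

Measured in a physicochemical assay for lipophilicity; on this read-out lower numbers stand for lower lipophilicity and higher numbers for higher lipophilicity:
compound 1 `Cc1nc(-c2cc(C(F)(F)F)ccc2[C@H]2CCOc3cc(S(=O)(=O)Nc4ncc(F)cn4)ccc32)co1`: 2.8
compound 2 `Cc1nc(-c2cc(C(F)(F)F)ccc2[C@@H]2CCOc3cc(S(=O)(=O)Nc4nccs4)ccc32)co1`: 2.9
compound 3 `Cc1nc(-c2cc(C(F)(F)F)ccc2[C@H]2CCOc3cc(S(=O)(=O)Nc4nccs4)ccc32)co1`: 2.9

All three lie within the scatter of one another, and compound 3 is level with compound 2. Compound 4 `O=S(=O)(Nc1nccs1)c1ccc2c(c1)OCC[C@@H]2c1ccc(C(F)(F)F)cc1-c1ccc(F)nc1` is not yet measured and differs from compound 3 in one place: 6-fluoropyridin-3-yl in place of 2-methyl-1,3-oxazol-4-yl on an aromatic carbon. In words, 6-fluoropyridin-3-yl stands in place of 2-methyl-1,3-oxazol-4-yl on an aromatic carbon.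

For the measured compounds named here, two measured steps bear on this only loosely: a number 0.10 log units higher from compound 1 to compound 3 (within the scatter), and no change at the digits printed from compound 2 to compound 3 (within the scatter), which rests on (the fact that compounds 2 and 3 differ only in the configuration as drawn). Neither changes the group replaced here, so the margin stays wide.

In this assay, the expected change is small and upward: a number 0.20 log units higher from compound 3 to compound 4 (within the scatter). The estimate for compound 4 is 3.1, with an expected range of 2.6 to 3.6.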

Compound 4, distribution coefficient: 3.2
Compound 4: the middle estimate sits 0.10 log units below what was measured; the range from low to high includes it.
By their numbers in this assay, from the lowest: compounds 1, 2, 3 and 4 (each within the scatter of the next, the first and the last beyond it).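

In this assay, the only change shown at this position, which is ortho to a large group and meta to a trifluoromethyl group, gives a number 0.30 log units higher from compound 3 to compound 4 (within the scatter). A six-membered aromatic ring carrying fluorine therefore stands here in place of a five-membered aromatic ring with two hetero atoms, and the step stays inside the scatter. Nothing shown gives a cause for this step.

Open, going by these compounds, is whether a morpholine or a carboxylic acid at this position would also stay within the scatter in this assay. Also open, on these data alone, is whether the same swap would behave alike with 5-fluoropyrimidin-2-yl on the sulfonamide nitrogen.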